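A Side-Group Exchange on Compound 1

The compounds below may be only part of what the source reports. "The series", "measured", "known", "first", "only" and "open" are said of these compounds alone.

Measured so far in a physicochemical assay for solubility, read by HPLC, in phosphate buffer, measured as kinetic solubility, with a stated time of 1 h, at pH 7.4, tested at 250 uM; on this read-out lower numbers stand for lower solubility and higher numbers for higher solubility:
- Compound 1 `CN1CCN(c2ccc3c(c2)oc(=O)n3C(=O)NCCCCc2ccccc2)CC1` gives < 1000 nM as a limit
- Compound 2 `CN1CCC(c2cc3oc(=O)n(C(=O)NCCCCc4ccccc4)c3cc2F)CC1` gives 70000 nM as a number

Compound 1 stands at the limit of < 1000 nM in this assay, at which 1 of the 2 values shown sits, so its entry is a limit and not a number. In compound 3 `CCN1CCC(c2ccc3c(c2)oc(=O)n3C(=O)NCCCCc2ccccc2)CC1` the change is 1-ethylpiperidin-4-yl in place of 4-methylpiperazin-1-yl on an aromatic carbon, counted as 1-ethylpiperidin-4-yl in place of 4-methylpiperazin-1-yl on an aromatic carbon with the rest of the core of compound 1 unchanged. For the measured compounds named here, no measured pair isolates this exchange, so the expectation is only tentative. Going by the values given here, it leans on compound 2 at 70000 nM as the sole number available in this assay and points to a rise beyond the scatter. The estimated change is an at least 30-fold higher number from compound 1 to compound 3 (1.47 log units; beyond the scatter) and it is expected to be upward. For compound 3 the expected value is 30000 nM within an estimated range of 5000 nM to 120000 nM.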

Compound 3, solubility: 198000 nM
For compound 3 the middle estimate is 6.6-fold (0.82 log units) below the measured one, and the stated range ends below it.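

At this aromatic carbon the exchange now rests on a direct pair: with the rest of the core unchanged, 1-ethylpiperidin-4-yl in place of 4-methylpiperazin-1-yl gives an at least 190-fold higher number from compound 1 to compound 3 (2.29 log units; beyond the scatter) in this assay. For the compounds shown here, this shows that one exchange at this position can move the read-out by a large step, beyond the scatter, which no earlier pair could show. The true size of the step stays open-ended because compound 1 stands at a limit and not at a number: the limit of < 1000 nM in this assay, at which 1 of the 3 values shown sits.

The exchange alters the ring and its nitrogen substituent together, so compound 1 and compound 3 do not show which of the two carries the step. Going by these compounds, a 4-ethylpiperazin-1-yl group on the same carbon would separate them, and an open-chain amine there remains untested by these compounds.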